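A few compounds are considered here, and "the series" means these few. Any claim that something is new, unique, unknown or untested is made for them only; others in the source may bear on it.

Of the compounds shown here, two with a shared core have been measured. Compound 1 `CN(C)CCC(OC(=O)c1cn(C)c2ccccc12)c1ccc(Cl)cc1` carries an indole ester, and in an assay on NIH3T3 cells with Urotensin-2 receptor (Homo sapiens) as the target (a lower number here means that less compound is needed, a higher number that more compound is needed for the effect), compound 1 gives 1510 nM. Compound 2 `Cc1ccsc1C(=O)OC(CCN(C)C)c1ccc(Cl)cc1` carries a thiophene ester instead, and in this assay compound 2 gives 2510 nM. This is numerically the larger of the two numbers, but the gap to compound 1 falls within the usual scatter of such measurements, so the two cannot be told apart.

Compound 3 `Cc1c(Cl)cccc1C(=O)OC(CCN(C)C)c1ccc(Cl)cc1` has not been measured. It differs from compound 2 in one place: 3-chloro-2-methylphenyl in place of 3-methylthiophen-2-yl on a carbonyl carbon. Among the measured compounds shown here, no measured pair shows what such an exchange does here, so the step is expected to stay small; the estimated step from compound 2 to compound 3 is a 1.1-fold lower number from compound 2 to compound 3 (0.06 log units; within the scatter), not beyond the scatter in either direction. For compound 3 the expected value in this assay is 2200 nM, with a likely range from 700 nM to 7000 nM.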

Compound 3, half-maximal effective concentration: 1120 nM
Estimate against measurement, compound 3: 2.0-fold (0.29 log units) above; measured number inside the range.
By their numbers in this assay, from the lowest: compounds 3, 1 and 2 (each within the scatter of the next, the first and the last beyond it).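

In this assay, among the compounds shown here, the exchange of 3-methylthiophen-2-yl for 3-chloro-2-methylphenyl on the carbonyl carbon gives a 2.2-fold lower number from compound 2 to compound 3 (0.35 log units; beyond the scatter) and is the first single change here to reach beyond the scatter, though only modestly. The group on this carbonyl carbon therefore does influence the number, and a six-membered aromatic ring of carbon only is accepted there without the number rising. Nothing available explains why the number falls with this exchange.

From the compounds shown here alone, the ring, the chlorine and the methyl group all differ between compound 2 and compound 3, so the share of each in the step remains unknown. Also open, going by these compounds, is what an unsubstituted phenyl, a pyridyl ring or a fluorine in place of the chlorine would do at this position.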